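Hydroxy in place of fluoro in compound 3

The source may hold more compounds than are shown below. What is called first, only, known or untested is meant among the compounds shown, and "the series" means these compounds.

Values so far in a functional assay on T47D cells (Homo sapiens) for inhibition, read by CCK-8 assay, with a stated time of 72 h, tested at 10 uM; a higher number here means more inhibition of growth at the concentration tested, a lower number less inhibition of growth:
compound 1 `CN(C)C(=O)c1cc2cnc(Nc3ccc(NC(=O)C4(C(=O)Nc5ccc(F)cc5)CC4)cc3)nc2n1C1CCCC1` gives 105%
compound 2 `Cc1cccc(NC(=O)C2(C(=O)Nc3ccc(Nc4ncc5cc(C(=O)N(C)C)n(C6CCCC6)c5n4)cc3)CC2)c1` gives 95.3%
compound 3 `CN(C)C(=O)c1cc2cnc(Nc3ccc(NC(=O)C4(C(=O)Nc5cccc(F)c5)CC4)cc3)nc2n1C1CCCC1` gives -0.4%

In this assay compound 3 (-0.4%) stands lowest of the three, clearly apart from the other two. Compound 4 `CN(C)C(=O)c1cc2cnc(Nc3ccc(NC(=O)C4(C(=O)Nc5cccc(O)c5)CC4)cc3)nc2n1C1CCCC1` differs from compound 3 in one place, with hydroxy in place of fluoro on an aromatic carbon, meta to a large group (hydroxy in place of fluoro on an aromatic carbon).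

Among the measured compounds shown here, three measured steps concern the same ring. The first, a number 9.7 percentage points lower from compound 1 to compound 2 (within the scatter), shows two quite different substituent patterns giving similar results. The other two are large: a number 105.4 percentage points lower from compound 1 to compound 3 (beyond the scatter) and a number 95.7 percentage points lower from compound 2 to compound 3 (beyond the scatter). Compound 2 carries methyl where compound 3 carries fluoro, so one small swap at this carbon has already moved the number across nearly the whole scale.

For the measured compounds named here, no measured compound carries a hydroxy group, so the data do not show which side compound 4 will fall on. With compound 3 already at the bottom and earlier steps on this ring so large, a rise is the more likely outcome, though a result near compound 3 remains possible. The expected change is a number 40.4 percentage points higher from compound 3 to compound 4 (beyond the scatter), and it is very uncertain. The estimate for compound 4 is 40% (expected range -5% to 95%).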

Compound 4, percent growth inhibition at one concentration: 83.7%
Beside the measured number, compound 4's estimate is 43.7 percentage points below it, and the stated range covers the measured number.
By their numbers in this assay, from the lowest: compound 3; then compound 4; then compounds 2 and 1 (each within the scatter of the next).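

In this assay, the step of a number 84.1 percentage points higher from compound 3 to compound 4 (beyond the scatter) shows that this carbon of the ring can still carry a high number: the low result belongs to fluoro there, not to every small group at that place. The hydroxy compound does not fully match the other two, though, with a number 11.6 percentage points lower from compound 2 to compound 4 (beyond the scatter) and a number 21.3 percentage points lower from compound 1 to compound 4 (beyond the scatter), both modest yet beyond the scatter, so methyl and hydroxy are not interchangeable here, and 3-hydroxyphenyl does not fully replace 4-fluorophenyl. Nothing available explains why fluoro alone at this carbon stands so far from methyl and hydroxy.

The compounds shown leave open whether the drop is peculiar to fluoro, since chloro, methoxy or an amine at this carbon could fall with either compound 3 or compound 4. From the compounds shown here alone, each number also comes from a single tested concentration, so it remains open whether the compounds with high numbers would keep the same order at lower concentrations, or whether compound 3 would show any effect at higher ones.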